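This account rests on a few compounds, and the source may have more. Where it says the series, first, only, none or still open, it means among the compounds named here.

Measured in a functional assay on HUVEC cells (Homo sapiens) for inhibition, with stated times of 2 h and 72 h; a higher number here means a weaker inhibitor, a lower number a stronger inhibitor:
- compound 1 `COc1cc2nccc(Oc3ccc4c(NC(=O)c5cccc(C(F)(F)F)c5)nn(C)c4c3)c2cc1OC`: > 1000 nM (a limit)
- compound 2 `COc1cc2nccc(Oc3ccc4c(NC(=O)c5cc(Cl)ccn5)nn(C)c4c3)c2cc1OC`: > 1000 nM (a limit)
- compound 3 `COc1ccc(C(=O)Nc2nn(C)c3cc(Oc4ccnc5cc(OC)c(OC)cc45)ccc23)cc1`: > 1000 nM (a limit)

In this assay compound 1 stands at > 1000 nM and this is a limit, not a number. The whole set sits there, as the limit of > 1000 nM in this assay, at which 3 of the 3 values shown sit, shows, so compound 1 has no rank within it.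

Next to be read is compound 4 `COc1cc2nccc(Oc3ccc4c(NC(=O)Nc5ccc(C)cc5)nn(C)c4c3)c2cc1OC`. The change from compound 1 is (4-methylphenyl)amino in place of 3-(trifluoromethyl)phenyl on a carbonyl carbon and it falls on a carbonyl carbon whose other neighbour is an amide-type nitrogen. Changes on that carbonyl carbon are a step that the two limits leave unreadable from compound 1 to compound 2 and a step that the two limits leave unreadable from compound 1 to compound 3 and also a step that the two limits leave unreadable from compound 2 to compound 3, so none offers a size to carry over. Among the compounds with values here, no measured compound has (4-methylphenyl)amino in that place.

The expected change is an at least 2.5-fold lower number from compound 1 to compound 4 (0.39 log units; beyond the scatter) and it is tentatively expected toward a stronger inhibitor. Compound 4 may still report only a limit. The range is wide because the limit of > 1000 nM in this assay, at which 3 of the 3 values shown sit, gives no readable step. For compound 4 the estimated value is 400 nM with an expected range from 20 nM to 3000 nM and this closes the note.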

Compound 4, half-maximal inhibitory concentration: > 1000 nM
Compound 4: a limit, no number; the forecaster's own chance of this, stated with the estimate: 40%; middle value at least 2.5-fold (0.39 log units) from the limit.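

In this assay compound 4 gives > 1000 nM, which is a limit. Within the data shown here, with compounds 1, 2 and 3 also reported only as limits, no step between any of them and compound 4 can be read. The compounds shown leave open how strong any of these four inhibitors actually is.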